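Methyl for hydrogen on the aryl ether chain, two cores

The source may hold more compounds than are shown below. What is called first, only, known or untested is meant among the compounds shown, and "the series" means these compounds.

Compound 1 `COc1cc2occ(-c3csc4ccccc34)c(=O)c2c(OC)c1OC` and compound 2 `CCOc1c(OC)cc2occ(-c3csc4ccccc34)c(=O)c2c1OC` share one core, compound 3 `COc1ccc(O)c(C(=O)/C=C/c2csc3ccccc23)c1` and compound 4 `CCOc1ccc(O)c(C(=O)/C=C/c2csc3ccccc23)c1` share another, and the difference between the two cores is not broken down here. In a functional assay on MDA-MB-231 cells (Homo sapiens) for antiproliferative activity, read by sulforhodamine B assay, with a stated time of 72 h (on this read-out higher numbers stand for weaker inhibition and lower numbers for stronger inhibition), compound 1 gives 820 nM, compound 2 gives 5200 nM and compound 3 gives 760 nM. The change from compound 1 to compound 2 methyl in place of hydrogen on a saturated chain carbon bound to an oxygen on an aromatic ring brought a 6.3-fold higher number from compound 1 to compound 2 (0.80 log units; beyond the scatter). The same change, at the same place, is made from compound 3 to compound 4 (methyl in place of hydrogen on a saturated chain carbon bound to an oxygen on an aromatic ring). Because a 6.3-fold higher number from compound 1 to compound 2 (0.80 log units; beyond the scatter) lies beyond the scatter, a step of similar size is expected for compound 4, namely a 4.6-fold higher number from compound 3 to compound 4 (0.66 log units; beyond the scatter), taking compound 3 at 760 nM as the starting point. Accordingly compound 4 is estimated at 3500 nM in this assay, with a likely range from 1200 nM to 9000 nM.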

Compound 4, half-maximal inhibitory concentration: 6700 nM
For compound 4 the middle estimate is 1.9-fold (0.28 log units) below the measured one, and the stated range covers the measured number.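

Methoxy to ethoxy on the core of compound 3 gives an 8.8-fold higher number from compound 3 to compound 4 (0.95 log units; beyond the scatter) in this assay. Set beside the step on the other core, the change carries over in direction, and the two sizes do not differ beyond the scatter: the same change on two cores in this assay, a 6.3-fold higher number (0.80 log units; beyond the scatter) from compound 1 to compound 2 and an 8.8-fold higher number (0.95 log units; beyond the scatter) from compound 3 to compound 4, 1.4-fold (0.14 log units) apart, within the scatter of two such steps. This agreement rests on two pairs on two cores in a single assay, so it does not show that the step would hold on any further core, and it gives no reason for the weaker inhibition.

Open, going by these compounds, is whether a longer chain such as propoxy, or an amine at the end of the chain, would continue the same trend. Also open, on these data alone, is whether the step holds outside this assay.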